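Phenyl for dichlorophenyl on the formyl-bearing core

This account rests on a few compounds, and the source may have more. Where it says the series, first, only, none or still open, it means among the compounds named here.

Within the data shown here, compound 2 `O=Cc1c(-c2ccc(Cl)cc2Cl)nc2sc(Cc3ccc(Cl)cc3)nn12` is the only member of this set with a numerical result: in a functional assay on L1210 cells (Mus musculus) for cytotoxicity, with a stated time of 48 h (a higher number here means a weaker inhibitor, a lower number a stronger inhibitor), compound 2 gives 82000 nM. Compound 1 `Clc1ccc(Cc2nn3c(Br)c(-c4ccccc4)nc3s2)cc1` returned only a limit of the assay; in this assay compound 1 gives > 250000 nM. Among the measured compounds shown here, of the two results so far, one therefore sits at the limit of > 250000 nM in this assay, at which 1 of the 2 values shown sits, and compound 2 stands as the sole measured number.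

Compound 3 `O=Cc1c(-c2ccccc2)nc2sc(Cc3ccc(Cl)cc3)nn12` is compound 2 with a single change, phenyl in place of 2,4-dichlorophenyl on an aromatic carbon. For the measured compounds named here, no measured step matches this change. Compound 3 is expected to be somewhat weaker than compound 2, with a step of a 2.4-fold higher number from compound 2 to compound 3 (0.39 log units; beyond the scatter) in this assay that is likely to exceed the scatter, though a near-flat outcome cannot be excluded. Compound 3 is estimated at 200000 nM in this assay, with a range from 60000 nM to 600000 nM.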

Compound 3, half-maximal inhibitory concentration: 20000 nM
Compound 3: the middle estimate sits 10-fold (1.00 log units) above what was measured; measured number below the stated range.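

At this aromatic carbon, the two chlorines of 2,4-dichlorophenyl are not needed for activity on the formyl-bearing core: phenyl in their place gives a 4.1-fold lower number from compound 2 to compound 3 (0.61 log units; beyond the scatter) in this assay. With phenyl held constant, formyl in place of bromo on an aromatic carbon gives an at least 12-fold lower number from compound 1 to compound 3 (1.09 log units; beyond the scatter), which points to the formyl-bearing carbon as a second position that affects the read-out. The size of that second step remains open-ended, as compound 1 carries a limit of the assay and not a number: the limit of > 250000 nM in this assay, at which 1 of the 3 values shown sits.

Going by these compounds, whether a single chloro or a methoxy on the phenyl ring would keep the gain over 2,4-dichlorophenyl remains open. The compounds shown also do not say whether the formyl group itself is required, or whether a hydroxymethyl group or a carboxylic acid on the same carbon would serve as well.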